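Methoxy in place of methyl: working notes on the series

A few compounds are considered here, and "the series" means these few. Any claim that something is new, unique, unknown or untested is made for them only; others in the source may bear on it.

Measured in an ADME assay on HaCaT cells (Homo sapiens) for inhibition, read by sulforhodamine B assay, with a stated time of 48 h; a higher number here means a weaker inhibitor of growth, a lower number a stronger inhibitor of growth:
- compound 1 `CC(C)(C)NCc1c(C(=O)O)nn(-c2ccccc2)c1-c1ccc(Br)cc1`: 366000 nM
- compound 2 `Cc1ccc(-c2c(CNC(C)(C)C)c(C(=O)O)nn2-c2ccccc2)cc1`: > 688000 nM (a limit)

Compound 2 stands at > 688000 nM as a limit of the assay and not a number. Compound 3 `COc1ccc(-c2c(CNC(C)(C)C)c(C(=O)O)nn2-c2ccccc2)cc1` carries methoxy in place of methyl on an aromatic carbon, para to a large group methoxy in place of methyl on an aromatic carbon on the shared core. Going by the values given here, the only measured step, an at least 1.8-fold higher number from compound 1 to compound 2 (0.27 log units; that floor lies within the scatter) for methyl in place of bromo on an aromatic carbon, has a floor within the scatter. No step beyond the scatter is therefore expected in this assay and no direction is favoured. The estimated step is an at least 1.1-fold lower number from compound 2 to compound 3 (0.05 log units; that floor lies within the scatter) and is expected to stay within the scatter. For compound 3 the expected value is 600000 nM with an estimated range of 300000 nM to 1200000 nM in this assay.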

Compound 3, concentration for 50% growth inhibition: > 659000 nM
Compound 3: only a limit was reported; the forecaster's own chance of this, stated with the estimate: 50%; middle value at least 1.0-fold (0.04 log units) away from the limit.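

In this assay compound 3 gives > 659000 nM, a limit of the assay and not a number. Compound 2 also stands at a limit, and the step between compound 2 and compound 3 cannot be read. Methoxy in place of bromo gives an at least 1.8-fold higher number from compound 1 to compound 3 (0.25 log units; that floor lies within the scatter), so methoxy, like methyl, has a floor on its step from bromo that does not pass the scatter.

As far as these compounds go, how far the true values of compound 2 and compound 3 lie past their limits stays open. From the compounds shown here alone, what an amine or a carboxylic acid at this position would give in this assay also stays open.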